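The source may hold more compounds than are shown below. What is called first, only, known or untested is meant among the compounds shown, and "the series" means these compounds.

Measured so far in an assay on isolated protein for displacement of a labelled ligand from growth hormone secretagogue receptor type 1 (Homo sapiens), with a stated time of 1 h; on this read-out higher numbers stand for weaker inhibition and lower numbers for stronger inhibition:
compound 1, `COC(=O)C(c1ccccc1)n1nnnc1[C@@H](COCc1ccccc1)NC(=O)C(C)(C)N`, gives 470 nM
compound 2, `CC(C)(N)C(=O)N[C@H](COCc1ccccc1)c1nnn(Cc2ccccc2)n1`, gives 4750 nM
compound 3, `COC(=O)C(c1ccccc1)n1nnc([C@@H](COCc2ccccc2)NC(=O)C(C)(C)N)n1`, reaches only a limit of the assay, > 5000 nM

Compound 1 holds the lowest of the two numbers; its nearest neighbour is compound 2, which sits at a higher number beyond the scatter. Going by the values given here, the single one-place step measured, an at least 1.0-fold higher number from compound 2 to compound 3 (0.02 log units; that floor lies within the scatter), runs from a number into a limit (the limit of > 5000 nM in this assay, at which 1 of the 3 values shown sits), so its true size is open. Compound 4 is `CCCCNC(=O)CCCn1nnnc1[C@@H](COCc1ccccc1)NC(=O)C(C)(C)N` and differs from compound 1 in 3-(butylcarbamoyl)propyl in place of methoxycarbonyl)(benzyl on an aromatic nitrogen. Among the compounds with values here, no measured step bears directly on this change: the one step available concerns methoxycarbonyl on the group attached to the other ring nitrogen, and compound 1 against compound 3 changes two places at once. What leaves in compound 4 is both benzyl and methoxycarbonyl; what enters is a chain carrying an amide and no ring. Without a step to lean on, a loss of modest size is expected from this exchange. The estimate for compound 4 in this assay is 1500 nM, with a range from 300 nM to 8000 nM. The expected step is a 3.2-fold higher number from compound 1 to compound 4 (0.50 log units; beyond the scatter).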

Compound 4, inhibition constant: 1780 nM
Compound 4: the middle estimate sits 1.2-fold (0.07 log units) below what was measured, within the range that was stated.
By their numbers in this assay, from the lowest: compound 1; then compound 4; then compound 2. At a limit, above all of these: compound 3.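

In this assay, exchanging the methoxycarbonyl and benzyl part of compound 1 for 3-(butylcarbamoyl)propyl on this aromatic nitrogen gives a 3.8-fold higher number from compound 1 to compound 4 (0.58 log units; beyond the scatter) and so costs a modest but real amount. The earlier compounds shown here gave no step at this position, and this one shows that a measured value survives here without the six-membered aromatic ring of carbon only: compound 4, whose entering chain has no ring and carries an amide, gives 1780 nM in this assay. Several features change together in this single exchange, and nothing measured here points to a cause for the step.

On these data alone, how the loss divides among the departure of the benzyl, the departure of the methoxycarbonyl and the arrival of the amide stays open, as would be tested by benzyl alone on this nitrogen. Equally open, as far as these compounds go, is how the position responds to other ends or lengths of the chain, such as a terminal carboxylic acid, a terminal amine or a longer chain.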